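The compounds below may be only part of what the source reports. "The series", "measured", "known", "first", "only" and "open" are said of these compounds alone.

Measured compounds in an ADME assay on A549 cells (Homo sapiens) for inhibition, read by MTT assay, with a stated time of 48 h; on this read-out higher numbers stand for weaker inhibition of growth and lower numbers for stronger inhibition of growth:

- compound 1 `Cc1ccc(OCc2cn(Cc3ccc(Cl)cc3)nn2)cc1` gives > 100 ug/mL, a limit of the assay.
- compound 2 `Cc1ccc(OCc2cn(Cc3cccc(Cl)c3)nn2)cc1` gives > 100 ug/mL, a limit of the assay.
- compound 3 `O=[N+]([O-])c1ccc(Cn2cc(COc3ccc(Cl)cc3)nn2)cc1` gives > 100 ug/mL, a limit of the assay.

Compound 2 stands only at a limit in this assay, and so do the other two measured compounds, as the evidence shows: the limit of > 100 ug/mL in this assay, at which 3 of the 3 values shown sit. For the measured compounds named here, the one single-point step among them, a step that the two limits leave unreadable from compound 1 to compound 2, is therefore unreadable in size and direction; the two limits leave nothing to compare. Compound 3 differs from compound 2 in more than one place and shows only its limit.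

Compound 4 `Clc1ccc(OCc2cn(Cc3cccc(Cl)c3)nn2)cc1` differs from compound 2 by chloro in place of methyl on an aromatic carbon. Going by the values given here, no measured step touches this change; the step from compound 1 to compound 2 moves the chlorophenyl on the saturated chain carbon bound to an aromatic nitrogen, not the group on the aromatic carbon, and it is unreadable anyway. The expectation for compound 4 in this assay can rest only on all three measured compounds sitting at the limit, so compound 4 is expected at 150 ug/mL, with a range of 60 ug/mL to 400 ug/mL. The expected step that the limit leaves unreadable from compound 2 to compound 4 is none beyond the scatter, most probably another limit.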

Compound 4, concentration for 50% growth inhibition: > 100 ug/mL
Compound 4: a limit, no number (the forecaster's own chance of this, stated with the estimate: 85%); the middle value is on the limit's open side.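

No new step can be read from compound 2 to compound 4, since both stand only at a limit: the limit of > 100 ug/mL in this assay, at which 4 of the 4 values shown sit.

The compounds shown leave open whether chloro in place of methyl on an aromatic carbon alters growth inhibition at all, and how the four compounds rank.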